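The source may report more compounds than this note shows. Statements on the series, on what has been measured and on what is new or still open speak of the compounds shown alone.

Compound 1, `Cc1cnn(C(=O)N2CCCN(Cc3ccc(OCc4ccccc4)cc3)CC2)c1`, gives 9500 nM in an assay on membranes from brain for binding affinity to Monoglyceride lipase (Mus musculus), read by fluorescence, with stated times of 1 h and 30 min; on this read-out higher numbers stand for weaker inhibition and lower numbers for stronger inhibition.
Compound 2, `CN(CCN(C)C(=O)n1cccn1)Cc1ccc(OCc2ccccc2)cc1`, gives 660 nM in this assay.
Compound 3, `Cc1cnn(C(=O)N(C)CCN(C)Cc2cccc(OCc3ccccc3)c2)c1`, gives 4100 nM in this assay.

Among these three numbers compound 3 holds the second highest place. Its nearest neighbour is compound 1, whose number is higher by a margin beyond the usual scatter, so compound 3 is the stronger inhibitor of the two. Compound 2 stands furthest away, with a clearly lower number, and is therefore the strongest inhibitor of the three measured compounds.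

Compound 4, `CN(CCN(C)C(=O)n1cc(C#N)cn1)Cc1cccc(OCc2ccccc2)c1`, has not yet been measured in this assay. It differs from compound 3 in one place: cyano in place of methyl on an aromatic carbon. Among the compounds with values here, no pair of measured compounds shows this same exchange, so the size of the step has to be guessed from the change alone. A moderate move toward a lower number in this assay, somewhat beyond the scatter, is expected here, with the step of a 2.7-fold lower number from compound 3 to compound 4 (0.44 log units; beyond the scatter) as the estimate of its size. On that basis compound 4 is expected to give about 1500 nM, within a range from 400 nM to 6000 nM.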

Compound 4, half-maximal inhibitory concentration: 590 nM
For compound 4 the middle estimate is 2.5-fold (0.41 log units) above the measured one, within the range that was stated.
By their numbers in this assay, from the lowest: compounds 4 and 2 (each within the scatter of the next); then compound 3; then compound 1.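

Replacing the 4-methyl-1H-pyrazol-1-yl group with the 4-cyano-1H-pyrazol-1-yl group gives a 6.9-fold lower number from compound 3 to compound 4 (0.84 log units; beyond the scatter) in this assay, which means stronger inhibition. Within the data shown here, this is the first pair here that differs in one place only, so it gives the first direct reading of this aromatic carbon, two ring bonds from the ring nitrogen, and shows that the group placed there can change the number by more than the usual scatter. The exchange adds one heavy atom, a triple bond and a hydrogen-bond acceptor, but nothing available here shows which of these features matters, and no measurement offers an explanation for the step.

As far as these compounds go, with a single exchange at this carbon, it remains open how other groups would compare there, such as a chlorine atom, a carboxamide or a longer chain like propyl. From the compounds shown here alone, it is also open whether the same exchange would give a step of similar size on the core of compound 1, where the open chain of compound 3 is replaced by a ring.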